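Shifting the methoxy group on an orexin receptor agonist amide

The source may hold more compounds than are shown below. What is called first, only, known or untested is meant among the compounds shown, and "the series" means these compounds.

Compound 1 `COc1cccc(C(=O)Nc2cccc3ccc(NS(=O)(=O)c4cc(-c5cccc(C(=O)N(C)C)c5)ccc4OC)cc23)c1` is the reference point of this small set. In a functional assay on CHO cells for agonist activity at Orexin receptor type 2 (Homo sapiens) (on this read-out higher numbers stand for larger maximal responses and lower numbers for smaller maximal responses), compound 1 gives 104%, a full response in this cell system. Compound 2 `COc1ccccc1C(=O)N(C)c1cccc2ccc(NS(=O)(=O)c3cc(-c4cccc(C(=O)N(C)C)c4)ccc3OC)cc12` carries the same sulfonamide-linked core but a methylated amide nitrogen bearing a 2-methoxyphenyl carbonyl group; in this assay compound 2 gives "nd" (no result reported), so no number is available for it and it cannot be placed against compound 1 on this read-out.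

Compound 3 `COc1cccc(C(=O)N(C)c2cccc3ccc(NS(=O)(=O)c4cc(-c5cccc(C(=O)N(C)C)c5)ccc4OC)cc23)c1` is the next structure, reached from compound 2 by the change (3-methoxyphenyl in place of 2-methoxyphenyl on a carbonyl carbon). Going by these compounds, since compound 2 has no value in this assay, no measured starting point exists for this step, and its size and direction remain open. Going by the values given here, the only anchor is the full response of compound 1, which shares the 3-methoxyphenyl carbonyl group of compound 3 but not its methylated nitrogen, and no step linking these two has been measured.

On that basis compound 3 is expected to reach a maximal response of about 70% in this assay, with a broad range from 10% to 110% reflecting the absence of data for compound 2.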

Compound 3, largest response reached (Emax), in percent of the reference or control that the assay uses: 102%
Beside the measured number, compound 3's estimate is 32 percentage points below it; the range from low to high includes it.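

Methyl in place of hydrogen on the amide-type nitrogen gives, in this assay, a number 2 percentage points lower from compound 1 to compound 3 (within the scatter), and compound 3 still gives a full response at 102%, which shows that within this pair the amide hydrogen is not required for a full response. The step from compound 2 to compound 3 cannot be read, as compound 2 has no reported number, which leaves the 2-methoxyphenyl and 3-methoxyphenyl groups uncompared on this read-out. Nothing at hand offers an explanation for this result.

Going by these compounds, it remains open whether the response holds with a longer chain such as ethyl in place of the methyl on the amide-type nitrogen, or with an amine or a carboxylic acid in place of the methoxy group on the phenyl ring of the 3-methoxyphenyl group. On these data alone, how much of each compound is needed to reach its response also stays open, as the largest response alone does not tell how compound 1 and compound 3 compare in potency.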